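The source may hold more compounds than are shown below. What is called first, only, known or untested is meant among the compounds shown, and "the series" means these compounds.

Measured compounds in a functional assay on MDA-MB-231 cells (Homo sapiens) for antiproliferative activity, read by MTT assay, with a stated time of 72 h; on this read-out lower numbers stand for stronger inhibition and higher numbers for weaker inhibition:
compound 1 `CC(=O)Nc1ccc(S(=O)(=O)Nc2cccc(-c3nc(-c4ccc(NC(=O)c5cccnc5)c(Cl)c4)no3)c2)cc1`, 4500 nM
compound 2 `CC(=O)Nc1ccc(S(=O)(=O)Nc2cccc(-c3nc(-c4ccc(NC(=O)c5cccnc5)c(C(F)(F)F)c4)no3)c2)cc1`, > 10000 nM
compound 3 `O=C(Nc1ccccc1)Nc1cccc(-c2nc(-c3ccc(NC(=O)c4cccnc4)cc3Cl)no2)c1`, > 10000 nM

Compound 3 gives no number in this assay; its result is only the limit of the assay. Compound 2 likewise stands at a limit, and the limit of > 10000 nM in this assay, at which 2 of the 3 values shown sit, is where two of the three results sit. Compound 1 alone carries a number.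

Compound 4 `CS(=O)(=O)Nc1ccc(NC(=O)Nc2cccc(-c3nc(-c4ccc(NC(=O)c5cccnc5)cc4Cl)no3)c2)cc1` departs from compound 3 by methanesulfonamido in place of hydrogen on an aromatic carbon. Among the measured compounds shown here, the single measured step, an at least 2.2-fold higher number from compound 1 to compound 2 (0.34 log units; beyond the scatter), concerns another position and another exchange, so no measured step bears on this change, and it gives no direction. Compound 4 is therefore expected to stay near the limit, with an estimated step of an at least 1.1-fold lower number from compound 3 to compound 4 (0.04 log units; that floor lies within the scatter). For compound 4 the estimate in this assay is 9000 nM, ranging from 3000 nM to 30000 nM.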

Compound 4, half-maximal inhibitory concentration: 600 nM
Beside the measured number, compound 4's estimate is 15-fold (1.18 log units) above it; measured number outside the range, below it.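

In this assay, methanesulfonamido in place of hydrogen, on an aromatic carbon para to a large group, gives an at least 16-fold lower number from compound 3 to compound 4 (1.22 log units; beyond the scatter). Among the compounds shown here, this is the first measured step at this position, and it shows that the ring tolerates the added group and that the change lifts the series clear of the limit. The step is only a floor, as compound 3 stands at a limit: the limit of > 10000 nM in this assay, at which 2 of the 4 values shown sit.

Going by these compounds, it remains open whether a smaller group, such as an amine or a methoxy, would do the same at this place. A carboxylic acid or a longer chain, such as ethanesulfonamido, is equally untested here.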